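Swapping one amine substituent on a shared core

The source may hold more compounds than are shown below. What is called first, only, known or untested is meant among the compounds shown, and "the series" means these compounds.

Compounds measured in an ADME assay on WI-38 cells (Homo sapiens) for cytotoxicity, read by MTT assay, with a stated time of 96 h; a higher number here means a weaker inhibitor, a lower number a stronger inhibitor
compound 1 `COc1ccc(CN2CCN(c3ccc(C4CC(c5ccc([N+](=O)[O-])o5)=NO4)cc3)CC2)cn1` gives > 50000 nM (a limit)
compound 2 `O=[N+]([O-])c1ccc(C2=NOC(c3ccc(-c4ccccn4)cc3)C2)o1` gives > 50000 nM (a limit)

In this assay compound 1 stands only at a limit and not at a number (> 50000 nM). Compound 2 also gives only a limit (> 50000 nM). Among the compounds with values here, the two measured compounds therefore sit at one point (the limit of > 50000 nM in this assay, at which 2 of the 2 values shown sit), and no measured step separates them.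

Compound 3 `CC(C)(C)OC(=O)N1CCN(c2ccc(C3CC(c4ccc([N+](=O)[O-])o4)=NO3)cc2)CC1` has the core of compound 1, with tert-butoxycarbonyl in place of (6-methoxypyridin-3-yl)methyl on an amine nitrogen in a ring. Within the data shown here, no measured step speaks directly to this change. The expected change is none beyond the scatter, in either direction (a number no higher from compound 1 to compound 3 (the limit leaves the size open)). This expectation rests on compound 2, whose different substitution still gives a limit (> 50000 nM). For compound 3 the estimated value is 50000 nM (expected range 20000 nM to 100000 nM).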

Compound 3, half-maximal inhibitory concentration: > 50000 nM
Compound 3 was reported as a limit; the forecaster's own chance of this, stated with the estimate: 70%; the middle value lies on the limit itself.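

Within the data shown here, compound 3, like compound 1, is reported only as a limit in this assay, so no step between the two can be read. The compounds shown leave open how far any of them lies beyond that limit, and whether tert-butoxycarbonyl and (6-methoxypyridin-3-yl)methyl differ at all in this assay.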